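Replacing the cyanocyclopropyl group with an oxadiazolyl ethyl group

The source may report more compounds than this note shows. Statements on the series, on what has been measured and on what is new or still open speak of the compounds shown alone.

Compound 1 `N#CC12CC(CN([C@H](CCC(F)(F)F)C(N)=O)S(=O)(=O)c3ccc(Cl)cc3)(C1)C2` reads 30.2 10^-6 cm/s
Compound 2 `N#CC1(CN([C@H](CCC(F)(F)F)C(N)=O)S(=O)(=O)c2ccc(Cl)cc2)CC1` reads 29.9 10^-6 cm/s

In an ADME assay on MDCKII-LE cells (Canis lupus familiaris) for permeability (a higher number here means that the compound crosses the layer faster, a lower number that the compound crosses the layer more slowly), compound 2 gives 29.9 10^-6 cm/s and compound 1 gives 30.2 10^-6 cm/s. The two stand level within the scatter, so compound 2 has no separate rank.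

Compound 3 `NC(=O)[C@@H](CCC(F)(F)F)N(CCCc1ncon1)S(=O)(=O)c1ccc(Cl)cc1` is the next to be read, and it differs from compound 2 as follows: 2-(1,2,4-oxadiazol-3-yl)ethyl in place of 1-cyanocyclopropyl on a saturated chain carbon bound to a sulfonamide nitrogen. In words, 2-(1,2,4-oxadiazol-3-yl)ethyl takes the place of 1-cyanocyclopropyl on a saturated chain carbon bound to a sulfonamide nitrogen.

Within the data shown here, only one measured step bears on this change: a 1.0-fold lower number from compound 1 to compound 2 (0.00 log units; within the scatter). That step exchanged one nitrile-bearing group for another at the same place and lay within the scatter. Among the measured compounds shown here, no measured compound carries the five-membered aromatic ring, so the data give little guidance on direction. The reading for compound 2 of 29.9 10^-6 cm/s therefore serves as the anchor, with a small downward shift allowed and no step beyond the scatter expected. The estimate corresponds to an expected 1.4-fold lower number from compound 2 to compound 3 (0.13 log units; within the scatter). For compound 3 the expected value is 22 10^-6 cm/s, with an estimated range from 11 10^-6 cm/s to 36 10^-6 cm/s.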

Compound 3, apparent permeability: 31.3 10^-6 cm/s
Compound 3: the middle estimate sits 1.4-fold (0.15 log units) below what was measured; the range from low to high includes it.
By their numbers in this assay, from the lowest: compounds 2, 1 and 3 (each within the scatter of the next).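

In this assay, among these compounds, 2-(1,2,4-oxadiazol-3-yl)ethyl in place of 1-cyanocyclopropyl gives a 1.0-fold higher number from compound 2 to compound 3 (0.02 log units; within the scatter), and the same group set against the one carried by compound 1 gives a 1.0-fold higher number from compound 1 to compound 3 (0.02 log units; within the scatter), so neither exchange leaves the scatter. Among the compounds shown here, until now, only two nitrile-bearing groups had been compared on this saturated chain carbon bound to a sulfonamide nitrogen; the series now includes a group with no nitrile, with one five-membered aromatic ring with 3 hetero atoms and 3 hydrogen-bond acceptors, and all three compounds still read within the scatter of one another. No measurement shown here accounts for this level reading.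

The compounds shown leave open whether the reading would stay within the scatter with an amine or a carboxylic acid on this chain, or with a longer chain carrying the 1,2,4-oxadiazole ring. They also leave open how these three compounds compare in any read-out other than this assay, since that is the only one given for them.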